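The compounds below may be only part of what the source reports. "The series", "measured", "known", "first", "only" and "open" are said of these compounds alone.

Compound 1 `Cc1ccc(-c2nnc(CSc3nnc(/N=C/c4ccccc4O)s3)o2)cc1`: 37100 nM in a functional assay on SMMC-7721 cells (Homo sapiens) for inhibition, read by CCK-8 assay; on this read-out lower numbers stand for stronger inhibition and higher numbers for weaker inhibition. Compound 2 `COc1ccc(-c2nnc(CSc3nnc(/N=C/c4ccccc4O)s3)o2)cc1`: 10000 nM. Compound 3 `O=[N+]([O-])c1cccc(-c2nnc(CSc3nnc(/N=C/c4ccccc4O)s3)o2)c1`: 15700 nM.

All three share one core and differ only in the group carried on one aromatic carbon. On these numbers compound 3 stands second highest of the three: its nearest neighbour is given by a 1.6-fold higher number from compound 2 to compound 3 (0.20 log units; within the scatter), its furthest by a 2.4-fold lower number from compound 1 to compound 3 (0.37 log units; beyond the scatter). Compound 4 `O=[N+]([O-])c1ccc(-c2nnc(CSc3nnc(/N=C/c4ccccc4O)s3)o2)cc1` differs from compound 3 in one place: 4-nitrophenyl in place of 3-nitrophenyl on an aromatic carbon. Going by the values given here, none of the measured steps bears on such a move; a 3.7-fold lower number from compound 1 to compound 2 (0.57 log units; beyond the scatter) and a 2.4-fold lower number from compound 1 to compound 3 (0.37 log units; beyond the scatter) exchange one group for a different one, and a 1.6-fold higher number from compound 2 to compound 3 (0.20 log units; within the scatter) lies within the scatter. A step of no size beyond the scatter is therefore expected in this assay, a 1.0-fold lower number from compound 3 to compound 4 (0.02 log units; within the scatter). Compound 4 is estimated at 15000 nM, within a range of 5000 nM to 45000 nM.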

Compound 4, half-maximal inhibitory concentration: 16900 nM
Compound 4: the middle estimate sits 1.1-fold (0.05 log units) below what was measured; low and high end bracket the measured number.
By their numbers in this assay, from the lowest: compounds 2, 3 and 4 (each within the scatter of the next); then compound 1.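

Exchanging 3-nitrophenyl for 4-nitrophenyl gives the first direct test of where the nitro group sits on this phenyl ring, and in this assay it shows a 1.1-fold higher number from compound 3 to compound 4 (0.03 log units; within the scatter). Nitro in place of methoxy gives a 1.7-fold higher number from compound 2 to compound 4 (0.23 log units; within the scatter), whereas nitro in place of methyl gives a 2.2-fold lower number from compound 1 to compound 4 (0.34 log units; beyond the scatter), so here only the comparison with the methyl compound lies beyond the scatter. Nothing available explains these numbers.

The compounds shown leave open how an amine or a carboxylic acid on this phenyl ring would read. They also leave open whether 3-methoxyphenyl would read like 4-methoxyphenyl.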